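Exchanging a Trifluoromethylphenyl Group on the Ring Amine

A few compounds are considered here, and "the series" means these few. Any claim that something is new, unique, unknown or untested is made for them only; others in the source may bear on it.

Three compounds from this study carry a number or a verdict in a functional assay on HL-60 cells (Homo sapiens) for inhibition, read by MTT assay, with a stated time of 72 h; on this read-out lower numbers stand for stronger inhibition and higher numbers for weaker inhibition. Compound 1 `COc1cc(OC)cc(N2CCN(C(=O)c3onc(C)c3-c3ccccc3)CC2)c1` gives 152 nM in this assay. Compound 2 `Cc1nc(-c2ccccc2)c(C(=O)N2CCN(c3cccc(C(F)(F)F)c3)CC2)o1` gives 153 nM in this assay, which is the higher of the two numbers, yet compound 1 and compound 2 lie within the scatter of each other, so no order between them can be read. Compound 3 `Cc1nc(-c2ccc(F)cc2)c(C(=O)N2CCN(c3ccc(Cl)cc3)CC2)o1` was reported as "not active" (no number reported) in this assay, without a number.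

The step under consideration leads from compound 2 to compound 4 `Cc1nc(-c2ccccc2)c(C(=O)N2CCN(c3ccc(C)c(C)c3)CC2)o1`, which is not yet measured. The change is 3,4-dimethylphenyl in place of 3-(trifluoromethyl)phenyl on an amine nitrogen in a ring. Among the compounds with values here, no measured pair in the set differs in one place, so nothing direct tells how large such an exchange is in this assay. Given that compound 2 gives 153 nM and that compound 3, with a different group on the same ring amine, was reported as not active, a modest move toward a higher number is expected for compound 4, with a 2.0-fold higher number from compound 2 to compound 4 (0.29 log units; within the scatter) as the estimated step. Compound 4 is therefore expected to give 300 nM in this assay, within a range from 80 nM to 1500 nM.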

Compound 4, half-maximal inhibitory concentration: 43 nM
Compound 4: the middle estimate sits 7.0-fold (0.84 log units) above what was measured; measured number below the stated range.
By their numbers in this assay, from the lowest: compound 4; then compounds 1 and 2 (each within the scatter of the next).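

In this assay, putting 3,4-dimethylphenyl in place of 3-(trifluoromethyl)phenyl on the amine nitrogen in the ring gives a 3.6-fold lower number from compound 2 to compound 4 (0.55 log units; beyond the scatter), the first measured size for an exchange at this position, and one that lies beyond the usual scatter. The earlier compounds shown here could not show this, since compound 1 and compound 3 each differ from compound 2 in more than one place; the new pair shows that the number responds to the aryl group on this nitrogen alone and that, with the rest of the molecule held fixed, the all-carbon group entering here gives the lower number without the three fluorine atoms of the group that leaves. No measurement in hand accounts for the size or direction of this step.

On these data alone, it remains open whether both methyl groups are needed, which a phenyl carrying a single methyl group or an unsubstituted phenyl would test, and whether a nitrile on the same ring would behave alike. Also open, as far as these compounds go, is whether the same exchange would lower the number on the core of compound 1.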